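The source may hold more compounds than are shown below. What is called first, only, known or untested is meant among the compounds shown, and "the series" means these compounds.

Measured so far:
compound 1 `COc1cc2c(Oc3ccc(NC(=O)c4cc(-c5ccccc5)ccn4)cc3F)ccnc2cc1OCCCN1CCN(C)CC1` — 150 nM
compound 2 `COc1cc2c(Oc3ccc(NC(=O)c4cc(-c5ccccc5F)ccn4)cc3F)ccnc2cc1OCCCN1CCCCC1` — 180 nM

In a functional assay on MKN-45 cells (Homo sapiens) for cytotoxicity, read by MTT assay, with a stated time of 72 h (a lower number here means a stronger inhibitor, a higher number a weaker inhibitor), compound 1 gives 150 nM and compound 2 gives 180 nM. Compound 2 stands with its number within the scatter of that of compound 1, so neither is set apart from the other. Compound 3 `COc1ccc(-c2ccnc(C(=O)Nc3ccc(Oc4ccnc5cc(OCCCN6CCCCC6)c(OC)cc45)c(F)c3)c2)cc1` differs from compound 2 by 4-methoxyphenyl in place of 2-fluorophenyl on an aromatic carbon. Going by the values given here, no measured pair differs in a single place, so the size of such a step has no measured precedent here. Compound 3 is expected to give about 200 nM, with a range of 80 nM to 500 nM. This corresponds to an expected step of a 1.1-fold higher number from compound 2 to compound 3 (0.05 log units; within the scatter), judged as no change beyond the scatter.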

Compound 3, half-maximal inhibitory concentration: 570 nM
Estimate against measurement, compound 3: 2.9-fold (0.45 log units) below, outside the stated range (above it).
By their numbers in this assay, from the lowest: compounds 1 and 2 (each within the scatter of the next); then compound 3.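

In this assay, going by these compounds alone, the aromatic carbon opposite the ring nitrogen proves sensitive to the aryl group it carries: 4-methoxyphenyl in place of 2-fluorophenyl gives a 3.2-fold higher number from compound 2 to compound 3 (0.50 log units; beyond the scatter) as the first single-place step. Compound 1 and compound 2 differ in more than one place, so they could not show this. Nothing measured here accounts for the step.

The change alters both the substituent and its place on the phenyl ring, so these remain unseparated. Open too, as far as these compounds go, is how 4-fluorophenyl, 2-methoxyphenyl or an aminophenyl group would compare at this carbon.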